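A few compounds are considered here, and "the series" means these few. Any claim that something is new, unique, unknown or untested is made for them only; others in the source may bear on it.

Of the compounds shown here, three have so far been measured in a functional assay on B16-F10 cells (Mus musculus) for antiproliferative activity, read by MTT assay, with a stated time of 48 h; on this read-out lower numbers stand for stronger inhibition and higher numbers for weaker inhibition. Compound 1 `Cc1ncc([N+](=O)[O-])n1CC(=O)NS(=O)(=O)c1ccc(F)cc1` gives 0.35 ug/mL in this assay. Compound 3 `Cc1ncc([N+](=O)[O-])n1CC(=O)NS(=O)(=O)c1ccccc1` gives 2.93 ug/mL. These two differ by hydrogen in place of fluoro on an aromatic carbon, and that change produced an 8.4-fold higher number from compound 1 to compound 3 (0.92 log units; beyond the scatter). Compound 2 `O=C(Cc1ccc(F)cc1)NS(=O)(=O)c1ccc(F)cc1`, built on a different core, gives 4.23 ug/mL in this assay; how the two cores differ is not broken down here. Compound 4 `O=C(Cc1ccc(F)cc1)NS(=O)(=O)c1ccccc1` has not yet been measured. It differs from compound 2 by hydrogen in place of fluoro on an aromatic carbon, the same change as before, at a place described in the same words: on an aromatic carbon of a six-membered aromatic ring of carbon only, para to a large group. The step from compound 2 to compound 4 is estimated as a 3.5-fold higher number from compound 2 to compound 4 (0.55 log units; beyond the scatter) in this assay, somewhat smaller than the earlier step, because the earlier step of an 8.4-fold higher number from compound 1 to compound 3 (0.92 log units; beyond the scatter) was seen on a different core and only once. Compound 4 is accordingly expected to give about 15 ug/mL in this assay, most likely between 5 ug/mL and 50 ug/mL.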

Compound 4, half-maximal inhibitory concentration: 9.07 ug/mL
Estimate against measurement, compound 4: 1.7-fold (0.22 log units) above, and the stated range covers the measured number.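

In this assay, taking the fluoro off the benzene ring of the sulfonyl side gave a 2.1-fold higher number from compound 2 to compound 4 (0.33 log units; beyond the scatter), so the loss of fluoro again goes with weaker inhibition. The direction of the change held on both cores, but its size did not carry over: the same change on two cores in this assay, an 8.4-fold higher number (0.92 log units; beyond the scatter) from compound 1 to compound 3 and a 2.1-fold higher number (0.33 log units; beyond the scatter) from compound 2 to compound 4, 3.9-fold (0.59 log units) apart, beyond the scatter of two such steps. A newcomer's rule of thumb that a step seen on one core can simply be added on another therefore fails here for size, though these four compounds cannot tell what in the cores sets the two steps apart, or how large the step would be on a third core.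

The compounds shown carry only fluoro or hydrogen at this place, so it stays open whether a chlorine atom, a methoxy group or an amine there would move the number in the same way on both cores. From the compounds shown here alone, it also stays open whether the two steps would keep their sizes in any test other than this assay.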